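A few compounds are considered here, and "the series" means these few. Any claim that something is new, unique, unknown or untested is made for them only; others in the source may bear on it.

Measured so far:
- Compound 1, `CCCCN(c1nc2c(C(=O)O)cccc2o1)[C@H](C)c1ccc(-c2ccccc2-c2nnn[nH]2)cc1`: 3.7 h
- Compound 2, `C[C@H](c1ccc(-c2ccccc2-c2nc(=O)o[nH]2)cc1)N(CC1CC1)c1nc2c(C(=O)O)cccc2o1`: 2.6 h

Both compounds were tested in an ADME assay on the whole organism (Macaca fascicularis) for metabolic stability, read by LC-MS, using cassette dosing, at a dose of 1 mg/kg by the oral route; a higher number here means that the compound lasts longer, a lower number that the compound disappears faster. Compound 1 gives 3.7 h and compound 2 gives 2.6 h; the gap between these two numbers is within the usual scatter of repeated measurements, so the two compounds cannot be told apart on this assay. For the measured compounds named here, there is no pair of measured compounds that differ in only one place, so nothing is yet known about how a single change shifts the half-life.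

The unmeasured compound 3, `CCCCN(c1nc2c(-c3nccn3C)cccc2o1)[C@H](C)c1ccc(-c2ccccc2-c2nnn[nH]2)cc1`, is derived from compound 1 by one change: 1-methyl-1H-imidazol-2-yl in place of carboxy on an aromatic carbon. The acid group is lost and a 1-methyl-1H-imidazol-2-yl ring takes its place on the shared core. Since no measured step of this kind exists, the expectation rests only on the two numbers shown, and the expected step from compound 1 to compound 3 in this assay, a 1.2-fold lower number from compound 1 to compound 3 (0.09 log units; within the scatter), is a small one, not beyond the scatter, with a slight lean downward. Compound 3 is therefore expected to give 3 h in this assay, with a likely range from 1.2 h to 7.5 h.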

Compound 3, half-life: 3.9 h
Beside the measured number, compound 3's estimate is 1.3-fold (0.11 log units) below it, within the range that was stated.
By their numbers in this assay, from the lowest: compounds 2, 1 and 3 (each within the scatter of the next).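

On the shared core, the aromatic carbon ortho to a fused ring and meta to a fused ring carries carboxy in compound 1 and 1-methyl-1H-imidazol-2-yl in compound 3, and this assay gives a 1.1-fold higher number from compound 1 to compound 3 (0.02 log units; within the scatter). For the compounds shown here, this is the first step that differs in only one place, and it shows that this exchange, which removes a hydrogen-bond donor and adds a five-membered aromatic ring, leaves the half-life within the scatter, so carboxy is not needed at this position for the compound to last as long in this assay. Nothing measured on these compounds explains this result.

This is a single step at a single position, so it sets no rule for other groups there, such as an amide, a nitrile or an amine, each of which could still give a half-life that stands clearly apart from these values. As far as these compounds go, it also remains open whether 1-methyl-1H-imidazol-2-yl in place of carboxy would give a similar result on the core of compound 2, which differs from compound 1 in more than one place.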